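The source may report more compounds than this note shows. Statements on the series, on what has been measured and on what is new or still open speak of the compounds shown alone.

Measured compounds:
compound 1, `COc1cc2ncnc(NNC(=S)NC(=O)c3ccccc3C)c2cc1OC`, 11400 nM
compound 2, `O=C(NC(=S)NNc1ncnc2ccccc12)c1ccc(C(F)(F)F)cc1`, 7920 nM
compound 3, `O=C(NC(=S)NNc1ncnc2ccccc12)c1cccc(Cl)c1`, 4740 nM

All three numbers come from a functional assay on KB cells (Homo sapiens) for cytotoxicity, read by MTT assay, with a stated time of 72 h; on this read-out lower numbers stand for stronger inhibition and higher numbers for weaker inhibition. Compound 1 gives the highest of the three numbers in this assay. Compound 2 sits a little lower, but within the scatter of compound 1, so no order between those two is claimed. Compound 3 sits further below compound 1, beyond the scatter, so compound 3 inhibits more strongly than compound 1 on this read-out. Among the compounds with values here, no two measured compounds differ in a single place, so the series gives no measured size for any one structural change; compounds 2 and 3 each differ from compound 1 in several places at once.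

The unmeasured compound 4 is `COc1cc2ncnc(NNC(=S)NC(=O)c3ccccc3)c2cc1OC`. Relative to compound 1 the change is: hydrogen in place of methyl on an aromatic carbon. The hydrogen that enters carries no heavy atom, and the group that leaves is a single carbon without ring, donors or acceptors.

Nothing measured here speaks to this change on its own. The step from compound 1 to compound 4 is therefore expected to be small, a 1.2-fold lower number from compound 1 to compound 4 (0.08 log units; within the scatter), with no direction beyond the scatter. Compound 4 is estimated at 9500 nM in this assay, with a range from 3500 nM to 26000 nM.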

Compound 4, half-maximal inhibitory concentration: 3770 nM
Compound 4: middle estimate off by 2.5-fold (0.40 log units), on the high side; low and high end bracket the measured number.
By their numbers in this assay, from the lowest: compounds 4, 3, 2 and 1 (each within the scatter of the next, the first and the last beyond it).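

In this assay, hydrogen in place of methyl on an aromatic carbon, ortho to a large group, gives a 3.0-fold lower number from compound 1 to compound 4 (0.48 log units; beyond the scatter), and this step lies beyond the scatter. Within the data shown here, it is the first size tied to one structural change, which the earlier compounds, each differing from compound 1 in several places at once, could not supply: on the core of compound 1, the benzoyl compound inhibits more strongly on this read-out than the (2-methylphenyl)carbonyl compound, so even a single carbon at this place registers. The data at hand offer no measurement that would account for this step.

From the compounds shown here alone, it remains open whether the step reflects the loss of the methyl alone or whether other groups on the same aromatic carbon, such as an ethyl, a methoxy or an amine, would give a number like that of compound 1 or that of compound 4. Going by these compounds, it also remains open whether 2-methylphenyl to phenyl would give a step of similar size and direction on the core shared by compound 2 and compound 3.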